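The source may report more compounds than this note shows. Statements on the series, on what has been measured and on what is new or still open speak of the compounds shown alone.

Compound 3, `NCc1ccc(C(=O)Nc2ccncc2F)cc1-c1cccc(NC(=O)c2ccc(C(=O)O)cc2)c1`, is the compound from which the step proceeds. In an assay on cells for inhibition of Rho-associated protein kinase 2 (Homo sapiens), read by radiometric assay and 33P incorporation, in the presence of a further agent that is not named here (a lower number here means a stronger inhibitor, a higher number a weaker inhibitor), compound 3 gives 1 nM, the lowest of the two numbers shown. Compound 1, `CCCOC(=O)c1cccc(C(=O)Nc2cccc(-c3cc(C(=O)Nc4ccncc4F)ccc3CN)c2)c1`, gives 1.8 nM in this assay, and the step of a 1.8-fold lower number from compound 1 to compound 3 (0.26 log units; within the scatter) lies within the scatter. Compound 2, `NCc1ccc(C(=O)Nc2ccncc2F)cc1-c1cccc(NC(=O)c2cc(C(=O)O)ccc2F)c1`, is reported in this assay only as a limit of the assay, < 1 nM, so the step of an at least 1.8-fold lower number from compound 1 to compound 2 (0.25 log units; that floor lies within the scatter) carries a floor, and the step of a number no lower from compound 2 to compound 3 (the limit leaves the size open) has no readable size; the limit of < 1 nM in this assay, at which 1 of the 3 values shown sits, describes this limit.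

Compound 4, `NCc1ccc(C(=O)Nc2ccncc2F)cc1-c1cccc(C(=O)Nc2ccccc2)c1`, is not yet measured. It differs from compound 3 in one place: phenylcarbamoyl in place of ((4-carboxyphenyl)carbonyl)amino on an aromatic carbon. The three measured steps all exchange one substituted benzoyl group for another while keeping the amide and its acidic or ester group; none removes the carboxylic acid or turns the amide around as this change does. Those steps were small or unreadable, so they give no direct guide here, and the change is larger than any of them.

Compound 4 is therefore expected to give a somewhat higher number in this assay, estimated at 8 nM, in a range from 1.5 nM to 50 nM, meaning an estimated step of an 8.0-fold higher number from compound 3 to compound 4 (0.90 log units; beyond the scatter).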

Compound 4, half-maximal inhibitory concentration: < 1 nM
Compound 4: a limit, no number (the forecaster's own chance of this, stated with the estimate: 5%); middle value at least 8.0-fold (0.90 log units) from the limit.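

In this assay compound 4 is reported only as a limit of the assay, < 1 nM. On this aromatic carbon, then, phenylcarbamoyl, with its amide turned around and with neither a carboxylic acid nor an ester, still gives a result at the end of the assay's range, which compound 1, compound 2 and compound 3 could not show, since each of them carries a benzoyl amide with an ester or a carboxylic acid. The step is a number no higher from compound 3 to compound 4 (the limit leaves the size open), so the change can be placed in no order of strength, and the assay offers little room to separate such compounds: the limit of < 1 nM in this assay, at which 2 of the 4 values shown sit.

The change turns the amide around and removes the carboxylic acid in one move, so the compounds shown leave open what each of the two does alone, which a plain benzoylamino group or a phenylcarbamoyl group bearing a carboxylic acid would address. They also leave open how an amine, a methoxy group or a longer chain on the phenyl ring of phenylcarbamoyl would read in this assay.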